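Swapping the dihydroxyphenyl group on a shared core

The compounds below may be only part of what the source reports. "The series", "measured", "known", "first", "only" and "open" are said of these compounds alone.

In a functional assay on DU-145 cells (Homo sapiens) for inhibition, read by trypan blue exclusion, with a stated time of 96 h (on this read-out lower numbers stand for stronger inhibition of growth and higher numbers for weaker inhibition of growth), compound 1 `O=C(/C(=C\c1ccc(O)c([N+](=O)[O-])c1)SCc1ccc(Br)cc1)c1ccc(Br)cc1` gives 10000 nM, and compound 2 `COc1ccc(C(=O)/C(=C\c2ccc(O)c([N+](=O)[O-])c2)SCc2ccc(Br)cc2)cc1` gives 10000 nM. These two differ only in one group on an aromatic carbon, and no change at the digits printed from compound 1 to compound 2 (within the scatter) shows that this swap made no real difference. Compound 3 `O=C(/C(=C\c1ccc(O)c([N+](=O)[O-])c1)SCc1ccc(Br)cc1)c1ccc(O)cc1O` reads > 100000 nM, which is a limit of the assay and not a number. It stands at the weak end of this small set, as shown by an at least 10-fold higher number from compound 1 to compound 3 (1.00 log units; beyond the scatter) and by an at least 10-fold higher number from compound 2 to compound 3 (1.00 log units; beyond the scatter).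

Compound 4 `O=C(/C(=C\c1ccc(O)c([N+](=O)[O-])c1)SCc1ccc(Br)cc1)c1ccc(C(F)(F)F)cc1` changes the group on the carbonyl carbon: 4-(trifluoromethyl)phenyl in place of 2,4-dihydroxyphenyl on a carbonyl carbon. The two steps into compound 3 are the closest guide, read in reverse, since compound 4 also lacks the 2,4-dihydroxyphenyl. The step of no change at the digits printed from compound 1 to compound 2 (within the scatter) further suggests that the group replacing it may matter little. The expected change is an at least 10-fold lower number from compound 3 to compound 4 (1.00 log units; beyond the scatter), towards stronger inhibition of growth. For compound 4 the estimate is 10000 nM, with an expected range of 3000 nM to 35000 nM.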

Compound 4, concentration for 50% growth inhibition: 10000 nM
Compound 4: middle estimate and measured number agree at the digits printed; the measured number falls inside the stated range.
By their numbers in this assay, from the lowest: compounds 1, 2 and 4 (each within the scatter of the next). At a limit, above all of these: compound 3.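

On the carbonyl carbon, 4-(trifluoromethyl)phenyl in place of 2,4-dihydroxyphenyl gives an at least 10-fold lower number from compound 3 to compound 4 (1.00 log units; beyond the scatter). Compound 3 stands at a limit and not at a number, so the full size of this step cannot be read: the limit of > 100000 nM in this assay, at which 1 of the 4 values shown sits. Trifluoromethyl also gives no change at the digits printed from compound 2 to compound 4 (within the scatter) and no change at the digits printed from compound 1 to compound 4 (within the scatter), so three different groups on this aromatic carbon read alike, while compound 3, with its 2,4-dihydroxyphenyl, goes against that pattern.

On these data alone, what remains open is whether one hydroxyl group or both go with the weak reading of compound 3, a question that a phenyl carrying a single hydroxyl would help to settle. As far as these compounds go, it is also open whether an amine or a carboxylic acid in place of the trifluoromethyl would read like compound 4 or like compound 3.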